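The compounds below may be only part of what the source reports. "The series", "measured", "known", "first", "only" and "open" are said of these compounds alone.

Working notes on the series. For the measured compounds named here, in a functional assay on MOLT-4 cells (Homo sapiens) for inhibition (a higher number here means a weaker inhibitor, a lower number a stronger inhibitor), compound 1 `O=C1CCCCC/C1=C\c1ccccc1` gives 215000 nM and compound 2 `O=C1CCCCC/C1=C\c1ccc(Br)cc1` gives 49400 nM, the lower of the two numbers so far. Compound 3 `COc1ccc(/C=C2\CCCCCC2=O)cc1` is the next to be read, and it differs from compound 2 at one place: methoxy in place of bromo on an aromatic carbon, para to a group of 9 heavy atoms (methoxy in place of bromo on an aromatic carbon).

Going by the values given here, only one measured step bears on this change: a 4.4-fold lower number from compound 1 to compound 2 (0.64 log units; beyond the scatter), a modest move that came with bromo in place of hydrogen at the same place. Among the compounds with values here, no methoxy compound has been measured, so that step gives a rough scale and no direct reading. With bromo leaving, part of that move is expected to be lost, so a modest rise in this assay is expected, smaller than the step to compound 2. The estimated change is a 2.0-fold higher number from compound 2 to compound 3 (0.31 log units; beyond the scatter), and its direction remains uncertain. For compound 3 the expected value is 100000 nM, with an estimated range of 35000 nM to 260000 nM.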

Compound 3, half-maximal inhibitory concentration: 250000 nM
Estimate against measurement, compound 3: 2.5-fold (0.40 log units) below; low and high end bracket the measured number.
By their numbers in this assay, from the lowest: compound 2; then compounds 1 and 3 (each within the scatter of the next).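

In this assay, methoxy in place of bromo gives a 5.1-fold higher number from compound 2 to compound 3 (0.70 log units; beyond the scatter), a modest step that removes the whole advantage seen with bromo rather than only part of it. Methoxy in place of hydrogen gives a 1.2-fold higher number from compound 1 to compound 3 (0.07 log units; within the scatter), within the scatter, so at this aromatic carbon, para to a group of 9 heavy atoms, a change of substituent does not by itself shift the number: bromo separates from hydrogen here, while methoxy does not, and compound 2 remains the only compound clearly apart from the others. No measurement available on these compounds accounts for this difference between bromo and methoxy.

Going by these compounds, with only hydrogen, bromo and methoxy read at this one place, it remains open whether the lower number belongs to bromo alone or extends to other halogens such as chloro or iodo, and how groups such as an amine, a carboxylic acid or a longer alkyl chain would read there. Also open, on these data alone, is whether bromo would give a step of similar size at another carbon of the aromatic ring or on a different core.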